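The compounds below may be only part of what the source reports. "The series", "measured", "known", "first", "only" and "open" are said of these compounds alone.

Compound 1 `COc1ccc(Sc2nc3cc(N)cc(N)c3nc2-c2ccccc2)cc1` and compound 2 `Nc1cc(N)c2nc(-c3ccccc3)c(Sc3ccc(Cl)c(Cl)c3)nc2c1` share one core and differ only in the group on the sulfur. In a functional assay on SK-MEL-5 cells (Homo sapiens) for inhibition, read by sulforhodamine B assay, with a stated time of 48 h (a higher number here means that more compound is tolerated, a lower number that less compound is tolerated), compound 1 gives < 100000 nM, which is a limit of the assay and not a number. In this assay compound 2 gives < 100000 nM, again a limit rather than a number. The change from compound 1 to compound 2, 3,4-dichlorophenyl in place of 4-methoxyphenyl on a sulfur, gives a step that the two limits leave unreadable from compound 1 to compound 2. Compound 2 thus stands at the same limit as compound 1, with nothing more known of where it lies, because of the limit of < 100000 nM in this assay, at which 2 of the 2 values shown sit. Compound 3 `Nc1cc(N)c2nc(-c3ccccc3)c(Sc3ccc(F)cc3)nc2c1` is not yet measured; it differs from compound 2 by 4-fluorophenyl in place of 3,4-dichlorophenyl on a sulfur. Among the measured compounds shown here, no measured step bears readably on this change. For compound 3 in this assay the step expected is a step that the limit leaves unreadable from compound 2 to compound 3, of no readable direction. Compound 3 is estimated at 30000 nM, within 5000 nM to 100000 nM, with a fair chance that only a limit is reported again.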

Compound 3, concentration lethal to 50% of the cells: 70800 nM
The estimate for compound 3 lay 2.4-fold (0.37 log units) below the measured number; low and high end bracket the measured number.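

Compound 1 and compound 2 remain limits of the assay and not numbers, so no step from either to compound 3 can be read: the limit of < 100000 nM in this assay, at which 2 of the 3 values shown sit.

Still open, going by these compounds, is whether the 4-methoxyphenyl, 3,4-dichlorophenyl and 4-fluorophenyl groups on the sulfur differ at all in this assay.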